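This account rests on a few compounds, and the source may have more. Where it says the series, first, only, none or still open, it means among the compounds named here.

Measured so far:
compound 1, `CCn1c(SCC(=O)Nc2ccc(C(C)=O)cc2)nnc1-c1ccc(OC)c(OC)c1` — 62%
compound 2, `CCn1c(SCC(=O)Nc2ccc(C(C)=O)cc2)nnc1-c1ccc(OC)cc1` — 57%

In a functional assay on the whole organism (strain albino) for inhibition, with Rattus norvegicus as the target, read by paw edema, with stated times of 30 min and 3 h, at a dose of 0.28 mmol/kg by the oral route (a higher number here means more inhibition at the dose given (going by the name of the read-out), a lower number less inhibition), compound 1 gives 62% and compound 2 gives 57%. Compound 2 carries the smaller of the two numbers shown, but the step of a number 5 percentage points lower from compound 1 to compound 2 (within the scatter) is within the scatter, so the two values are not separated.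

Compound 3, `C=CCn1c(SCC(=O)Nc2ccc(C(C)=O)cc2)nnc1-c1ccc(OC)cc1`, differs from compound 2 by vinyl in place of methyl on a saturated chain carbon bound to an aromatic nitrogen. Among the compounds with values here, the only measured step concerns a methoxy on an aromatic carbon, not the chain on the aromatic nitrogen, so no measured step bears on this change. With the shared core and the rest of the structure unchanged, nothing in the series points to a shift in either direction. The step expected here is no change at the digits printed from compound 2 to compound 3 (within the scatter), none beyond the scatter. In this assay compound 3 is therefore estimated at 57%, with a range from 44% to 70%.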

Compound 3, a percentage reported as inhibition, in the whole organism at one dose (the size of the read-out at that dose, not a potency): 52%
Beside the measured number, compound 3's estimate is 5 percentage points above it; measured number inside the range.
By their numbers in this assay, from the lowest: compounds 3, 2 and 1 (each within the scatter of the next).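

In this assay, replacing ethyl with allyl on the aromatic nitrogen gives a number 5 percentage points lower from compound 2 to compound 3 (within the scatter), so the two values are not separated. Within the data shown here, this is the first reading at this position: the earlier step concerned only a methoxy on an aromatic carbon, and the series now has a second place where a single change leaves the read-out within the scatter. No supporting data accompany this result that would account for the small step or connect it to any feature of the vinyl end of the chain.

Still open, from the compounds shown here alone, is how this position responds to groups further from ethyl and allyl, such as a longer chain like hexyl, a benzyl group or a chain ending in an amine. Also open, going by these compounds, is whether the same change reads alike with the extra methoxy of compound 1 in place.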